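Indolylsulfanyl pyrimidinyl ureas: HepG2 inhibition notes

The compounds below may be only part of what the source reports. "The series", "measured", "known", "first", "only" and "open" are said of these compounds alone.

Measured so far:
compound 1 `O=C(Nc1ccccc1)Nc1nc(Nc2ccccc2)cc(Sc2c[nH]c3ccccc23)n1`: 14400 nM
compound 2 `Cc1cc(Cl)ccc1NC(=O)Nc1nc(Nc2ccccc2)cc(Sc2c[nH]c3ccccc23)n1`: 8370 nM

In a functional assay on HepG2 cells (Homo sapiens) for inhibition, with a stated time of 72 h (on this read-out lower numbers stand for stronger inhibition and higher numbers for weaker inhibition), compound 1 gives 14400 nM and compound 2 gives 8370 nM. Going by the values given here, the one measured step, a 1.7-fold lower number from compound 1 to compound 2 (0.24 log units; within the scatter), is within the scatter, so compound 2 has the lowest of the two numbers without being separable from compound 1.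

Compound 3 `Cc1cc(Cl)ccc1NC(=O)Nc1nc(Sc2c[nH]c3ccccc23)cc(N2CCN(c3ccccn3)CC2)n1` is not yet measured. It differs from compound 2 by 4-(pyridin-2-yl)piperazin-1-yl in place of anilino on an aromatic carbon, on an aromatic carbon of a six-membered aromatic ring with 2 nitrogen. Among the compounds with values here, the measured step concerns a different place, the amide-type nitrogen, and no measured pair shows an exchange at this aromatic carbon. Nothing in the series therefore speaks for a step beyond the scatter in this assay, and the expected step for compound 3 is a 1.2-fold higher number from compound 2 to compound 3 (0.08 log units; within the scatter). On these data alone, compound 3 is thus estimated at 10000 nM, with a range from 3000 nM to 40000 nM, the width reflecting that the change is untested.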

Compound 3, half-maximal inhibitory concentration: 7640 nM
The estimate for compound 3 lay 1.3-fold (0.12 log units) above the measured number, and the stated range covers the measured number.
By their numbers in this assay, from the lowest: compounds 3, 2 and 1 (each within the scatter of the next).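

In this assay, the first exchange shown at the aromatic carbon next to the ring nitrogen, 4-(pyridin-2-yl)piperazin-1-yl in place of anilino, gives a 1.1-fold lower number from compound 2 to compound 3 (0.04 log units; within the scatter). In this pair, the position takes a group of 12 heavy atoms in place of one of 7, and the anilino hydrogen-bond donor and carbon-only aromatic ring can be lost without a step beyond the scatter. No supporting data on the compounds bear on this result.

The compounds shown leave open whether any group at this carbon gives a step beyond the scatter, for example a simple amine, morpholine, or a piperazine carrying a carboxylic acid on a longer chain. They also leave open whether the 4-(pyridin-2-yl)piperazin-1-yl exchange behaves the same way with phenyl on the urea.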